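Pyridin-2-yl for phenyl on two related cores

The source may hold more compounds than are shown below. What is called first, only, known or untested is meant among the compounds shown, and "the series" means these compounds.

Compound 1 `Cn1nc(N)c2c(=O)[nH]c(-c3ccccc3)cc21` and compound 2 `Cn1nc(N)c2c(=O)[nH]c(-c3ccccn3)cc21` share one core; compound 3 `Nc1c2c(=O)[nH]c(-c3ccccc3)cc2nn1-c1ccccc1` is built on a second core, and the difference between the two cores is not broken down here. In an assay on isolated protein for inhibition of ribosomal protein S6 kinase alpha-1 (Homo sapiens), read by mobility shift assay, tested at 30 uM (on this read-out lower numbers stand for less inhibition and higher numbers for more inhibition at the one concentration tested (going by the name of the read-out)), compound 1 gives 8%. In this assay compound 2 gives 9%. The change pyridin-2-yl in place of phenyl on an aromatic carbon therefore produced a number 1 percentage points higher from compound 1 to compound 2 (within the scatter), so on the core of compound 1 this exchange left the read-out essentially unchanged. In this assay compound 3 gives 38%, the highest of the three numbers, and its gap to compound 2 as well as to compound 1 lies beyond the scatter.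

Compound 4 `Nc1c2c(=O)[nH]c(-c3ccccn3)cc2nn1-c1ccccc1` has not been measured. It differs from compound 3 by pyridin-2-yl in place of phenyl on an aromatic carbon, which is the same change as that from compound 1 to compound 2, made at the same place on the other core. Going by the values given here, the only precedent for the exchange is a single pair, and it sits on a different core than compound 3, so the transfer is not secured by more than one observation.

The expected step is a number 2 percentage points higher from compound 3 to compound 4 (within the scatter). This rests on compound 1 and compound 2, whose measured step was a number 1 percentage points higher from compound 1 to compound 2 (within the scatter). Compound 4 is expected to give about 40% in this assay. The expected range for compound 4 runs from 25% to 55%, wider than the scatter alone because the precedent a number 1 percentage points higher from compound 1 to compound 2 (within the scatter) comes from one pair on another core.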

Compound 4, a percentage reported as inhibition, at one concentration (the size of the read-out at that concentration, not a potency): 6%
The estimate for compound 4 lay 34 percentage points above the measured number; the whole stated range lies above it.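

Pyridin-2-yl in place of phenyl on the core of compound 3 gave a number 32 percentage points lower from compound 3 to compound 4 (beyond the scatter) in this assay, so on this core the exchange is far from neutral. Set beside the earlier pair, the exchange does not carry over from one core to the other in this series: the same change on two cores in this assay, a number 1 percentage points higher (within the scatter) from compound 1 to compound 2 and a number 32 percentage points lower (beyond the scatter) from compound 3 to compound 4, 33 percentage points apart, beyond the scatter of two such steps This shows that a neutral result on the core of compound 1 gave no safe guide to the result on the core of compound 3, but with a single pair on each core it gives no general rule and does not show which part of the cores accounts for the difference.

Open, from the compounds shown here alone, is whether the loss on the core of compound 3 is specific to pyridin-2-yl or extends to other replacements of phenyl at this place next to the ring nitrogen, such as pyridin-3-yl, pyridin-4-yl or a phenyl ring carrying an amine or a carboxylic acid. Also open, going by these compounds, is how the same exchange behaves on further cores, for instance with an ethyl or a benzyl group at the place where compound 1 and compound 3 differ.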